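The compounds below may be only part of what the source reports. "The series", "measured", "known", "first", "only" and "open" are said of these compounds alone.

Total growth inhibition in a functional assay on IGROV-1 cells (Homo sapiens) for inhibition, read by sulforhodamine B assay, with a stated time of 48 h; on this read-out lower numbers stand for stronger inhibition of growth and higher numbers for weaker inhibition of growth:
- compound 1 `Cc1ccc(C2=NN(c3ccc(S(C)(=O)=O)cc3)C(=O)CC2)cc1`: > 100000 nM (a limit)
- compound 2 `Cc1cc(O)ccc1C1=NN(c2ccc(S(C)(=O)=O)cc2)C(=O)CC1`: > 100000 nM (a limit)

Compound 2 stands at the limit of > 100000 nM in this assay, at which 2 of the 2 values shown sit, which is a limit and not a number. Compound 3 `CCc1ccc(C2=NN(c3ccc(S(C)(=O)=O)cc3)C(=O)CC2)cc1` differs from compound 2 by 4-ethylphenyl in place of 4-hydroxy-2-methylphenyl on a carbon with a double bond to nitrogen. Among the measured compounds shown here, the only measured step that bears on this change is a step that the two limits leave unreadable from compound 1 to compound 2, and it offers no size to carry over. With no readable step to build on, no step beyond the scatter is expected in this assay, and a further limit is the likeliest report. The expected step is a number no higher from compound 2 to compound 3 (the limit leaves the size open). Compound 3 is estimated at 100000 nM, with an expected range of 40000 nM to 100000 nM.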

Compound 3, concentration for total growth inhibition: 55200 nM
Beside the measured number, compound 3's estimate is 1.8-fold (0.26 log units) above it; the range from low to high includes it.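

Compound 3 is the only compound shown that gives a number and not a limit in this assay. The 4-ethylphenyl group in place of 4-hydroxy-2-methylphenyl gives an at least 1.8-fold lower number from compound 2 to compound 3 (0.25 log units; that floor lies within the scatter), and methyl in place of hydrogen on a saturated chain carbon bound to an aromatic carbon gives an at least 1.8-fold lower number from compound 1 to compound 3 (0.25 log units; that floor lies within the scatter). Neither floor establishes a change beyond the scatter, and the step between the two limits cannot be read.

Open, going by these compounds, is whether a longer chain such as propyl, or an amine, in place of the ethyl of 4-ethylphenyl would move the number beyond the scatter. Most of the set still rests on a limit: the limit of > 100000 nM in this assay, at which 2 of the 3 values shown sit.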